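A few compounds are considered here, and "the series" means these few. Any claim that something is new, unique, unknown or untested is made for them only; others in the source may bear on it.

Of the compounds shown here, two have been measured in a functional assay for inhibition of sodium/hydrogen exchanger (Oryctolagus cuniculus); a lower number here means a stronger inhibitor, a higher number a weaker inhibitor. Compound 1 `CCCc1cc(C)c(C(=O)N=C(N)N)cc1S(C)(=O)=O` gives 5.7 nM in this assay. Compound 2 `Cc1cc(O)c(S(C)(=O)=O)cc1C(=O)N=C(N)N` gives 220 nM in this assay, which is the highest of the two numbers shown; the only other value is that of compound 1, and the step of a 39-fold higher number from compound 1 to compound 2 (1.59 log units; beyond the scatter) came with a hydroxy in place of a propyl on an aromatic carbon.

Compound 3 `Cc1cc(OC(C)C)c(S(C)(=O)=O)cc1C(=O)N=C(N)N` has not yet been measured in this assay. It differs from compound 2 in one place: isopropyl in place of hydrogen on an oxygen on an aromatic ring, so that the hydroxy of compound 2 becomes an isopropoxy. Among the measured compounds shown here, this puts a three-carbon group back into the place where compound 1 carries its propyl, which makes the step from compound 1 to compound 2 the one measured step that bears on this change. Since that step was large, a large step back in the other direction is expected, though not necessarily all the way to compound 1. Compound 3 is therefore estimated at 15 nM in this assay, with a range from 4 nM to 60 nM, a step of a 15-fold lower number from compound 2 to compound 3 (1.17 log units; beyond the scatter) expected from compound 2 to compound 3.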

Compound 3, half-maximal inhibitory concentration: 19 nM
For compound 3 the middle estimate is 1.3-fold (0.10 log units) below the measured one; the measured number falls inside the stated range.
By their numbers in this assay, from the lowest: compound 1; then compound 3; then compound 2.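

Turning the hydroxy of compound 2 into an isopropoxy gives a 12-fold lower number from compound 2 to compound 3 (1.06 log units; beyond the scatter) and so recovers much of the ground lost when a hydroxy replaced the propyl of compound 1. The weak value of compound 2 is therefore not a fixed penalty for having an oxygen on this aromatic carbon, since a change made only on that oxygen, with the isopropyl taking the place of its hydrogen, reverses most of it. The recovery is incomplete, however, as the comparison with the propyl compound shows a 3.3-fold higher number from compound 1 to compound 3 (0.52 log units; beyond the scatter) and this modest gap means that isopropoxy does not fully match propyl here.

No measurement beyond these inhibition numbers bears on why either step occurs. Going by these compounds, it remains open how a smaller methoxy, a longer chain such as butoxy, or an amine in this place would compare, and so whether the isopropyl itself matters or simply the loss of the hydroxy hydrogen.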